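The compounds below may be only part of what the source reports. "The series", "measured", "known", "first", "only" and "open" are said of these compounds alone.

Working notes on the series. The shared core carries a substituted phenyl group at one end; compound 1 `COc1cc(OC)c2c(=O)cc(-c3ccc(OCCF)cc3)oc2c1` bears a 2-fluoroethoxy group there and compound 2 `COc1cc(OC)c2c(=O)cc(-c3ccc(NCCN(C)C)cc3)oc2c1` a (2-(dimethylamino)ethyl)amino group in the same place. In a functional assay (Homo sapiens) for antiproliferative activity, read by resazurin assay, with a stated time of 48 h, tested at 10 uM (on this read-out lower numbers stand for a weaker effect and higher numbers for a stronger effect at the one concentration tested), compound 1 gives "not active" (no number reported), a result without a number, so no single figure places it on the scale; in this assay compound 2 gives 60%.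

Compound 3 `COc1cc(OC)c2c(=O)cc(-c3ccc(NCCN4CCCC4)cc3)oc2c1` has not been measured. Compared with compound 1 the change is (2-(pyrrolidin-1-yl)ethyl)amino in place of 2-fluoroethoxy on an aromatic carbon, on an aromatic carbon of a six-membered aromatic ring of carbon only. For the measured compounds named here, no step between measured compounds covers this exchange. Since compound 1 shows no number in this assay, the step cannot be given as a figure, but an increase well beyond the usual scatter is expected, toward the level of compound 2. By comparison with compound 2, compound 3 is expected to give 55%, in the range 30% to 80%.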

Compound 3, a percentage reported as inhibition, at one concentration (the size of the read-out at that concentration, not a potency): 51%
The estimate for compound 3 lay 4 percentage points above the measured number, and the stated range covers the measured number.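

In this assay, pyrrolidin-1-yl in place of dimethylamino on the chain gives a number 9 percentage points lower from compound 2 to compound 3 (within the scatter), so closing the terminal amine into a five-membered non-aromatic ring does not separate the two compounds on this read-out. A second amine-bearing chain on the aromatic carbon now gives a number, whereas compound 1, with 2-fluoroethoxy, gives "not active" (no number reported), so the contrast with compound 1 rests on two compounds rather than one. No measurement is at hand that explains this contrast.

As far as these compounds go, it remains open which part of the chain goes with the effect: a 2-(dimethylamino)ethoxy group or a plain ethylamino group in the same place would separate the nitrogen on the aromatic ring from the terminal amine. Also open, from the compounds shown here alone, is whether a piperidin-1-yl or morpholin-4-yl end group, or a longer chain between the two nitrogens, would hold this level.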